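The source may report more compounds than this note shows. Statements on the series, on what has been measured and on what is new or still open speak of the compounds shown alone.

In a functional assay on A549 cells (Homo sapiens) for inhibition (a lower number here means a stronger inhibitor, a higher number a weaker inhibitor), compound 1 `COC(=O)C(C(=O)OC)C1CC(=O)C=CC12OCC(=O)N2Cc1ccc(C)cc1` gives 9250 nM and compound 2 `COC(=O)C(C(=O)OC)C1CC(=O)C=CC12OCC(=O)N2Cc1ccc(Br)cc1` gives 2550 nM. Compound 3 `CCSC1CC(=O)CC(SCC)C12OCC(=O)N2Cc1ccc(C)cc1`, which has other groups on the core, gives 2300 nM. Within the data shown here, that number lies within the scatter of the one for compound 2, and clearly under the one for compound 1.

Compound 4 `CCSC1CC(=O)CC(SCC)C12OCC(=O)N2Cc1ccc(Cl)cc1` differs from compound 3 in a single place: chloro in place of methyl on an aromatic carbon. In words, this is chloro in place of methyl on an aromatic carbon, turning 4-methylbenzyl into 4-chlorobenzyl. The closest measured change replaces methyl with bromo rather than chloro, and it gives a 3.6-fold lower number from compound 1 to compound 2 (0.56 log units; beyond the scatter). Among the measured compounds shown here, this modest step is the only guide, and it was measured with other groups on the core, so it may not carry over in full. Based on it, a modest step toward a lower number is expected in this assay, perhaps slightly smaller and possibly within the scatter. The expected change is a 2.3-fold lower number from compound 3 to compound 4 (0.36 log units; beyond the scatter). For compound 4, the estimated value is 1000 nM, with an expected range of 400 nM to 2500 nM.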

Compound 4, half-maximal inhibitory concentration: > 10000 nM
Compound 4: only a limit was reported (the forecaster's own chance of this, stated with the estimate: 2%); middle value at least 10-fold (1.00 log units) away from the limit.
By their numbers in this assay, from the lowest: compounds 3 and 2 (each within the scatter of the next); then compound 1. At a limit, above all of these: compound 4.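

With the ethylthio groups on the core, chloro in place of methyl on an aromatic carbon para to a large group gives an at least 4.3-fold higher number from compound 3 to compound 4 (0.63 log units; beyond the scatter) in this assay. The result for compound 4 is a limit of the assay, not a number: the limit of > 10000 nM in this assay, at which 1 of the 4 values shown sits. The earlier step, a 3.6-fold lower number from compound 1 to compound 2 (0.56 log units; beyond the scatter), ran the other way with bromo and with other groups on the core, so the effect of replacing methyl at this position does not carry over unchanged between these two compounds pairs.

The compounds shown cannot separate the role of the core from that of chloro versus bromo, as each halogen appears on only one core. From the compounds shown here alone, how a methoxy group or an amine at this position would behave on either core also stays open.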